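The source may hold more compounds than are shown below. What is called first, only, known or untested is meant among the compounds shown, and "the series" means these compounds.

Measured so far:
compound 1, `CCCCNc1nc(N)nc(C)c1CCCN1CCN(C)CC1`, this compound gives 179 nM in an assay on HEK293 cells for agonist activity at Toll-like receptor 8 (Homo sapiens), read by spectrophotometry; on this read-out lower numbers stand for an effect already at smaller amounts and higher numbers for an effect only at larger amounts of compound;
compound 2, `CCCCNc1nc(N)nc(C)c1CCC(C)(C)O`, this compound gives 3140 nM in this assay.

Compound 2 stands at the highest of the two numbers seen so far in this assay; its nearest neighbour, compound 1, sits at a markedly lower number, and the gap between the two lies beyond the scatter of repeated measurements. Among the compounds with values here, no pair of these two compounds differs in one place only, so the two values are taken only as what they show.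

The unmeasured compound 3, `CCCCNc1nc(N)nc(C)c1CCCc1ccccc1`, is reached from compound 2 by the change (benzyl in place of 1-hydroxy-1-methylethyl on a saturated chain carbon, two bonds along the chain from an aromatic carbon). Nothing in the two measured compounds speaks directly to this change, since neither of them carries a benzyl at that position. The expectation for this assay is a step in the direction of a lower number, of moderate size, with wide uncertainty around it. For compound 3 in this assay the estimated value is 1000 nM, within a range from 250 nM to 5000 nM, which means an expected step of a 3.1-fold lower number from compound 2 to compound 3 (0.50 log units; beyond the scatter).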

Compound 3, half-maximal effective concentration: 749 nM
The estimate for compound 3 lay 1.3-fold (0.13 log units) above the measured number; the range from low to high includes it.
By their numbers in this assay, from the lowest: compound 1; then compound 3; then compound 2.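

In this assay, this position now has two comparisons that each differ in one place, which the earlier pair of compounds could not provide: benzyl in place of 1-hydroxy-1-methylethyl on a saturated chain carbon, two bonds along the chain from an aromatic carbon, gives a 4.2-fold lower number from compound 2 to compound 3 (0.62 log units; beyond the scatter), and phenyl in place of 4-methylpiperazin-1-yl on a saturated chain carbon, three bonds along the chain from an aromatic carbon, gives a 4.2-fold higher number from compound 1 to compound 3 (0.62 log units; beyond the scatter). Both steps lie beyond the scatter and run in opposite directions towards compound 3, so the number in this assay depends on what the chain carries here, and a six-membered aromatic ring of carbon only, with no hydrogen-bond donor or acceptor, is compatible with a number in the nanomolar range. Nothing available accounts for either step.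

The compounds shown leave open whether a primary amine, a carboxylic acid or a morpholine at this position would give a lower or higher number than the phenyl of compound 3. They also leave open how a substituted phenyl, or a longer chain carrying the phenyl, would read in this assay.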